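The compounds below may be only part of what the source reports. "The series", "measured", "known", "first", "only" and "open" are said of these compounds alone.

Compound 1 `CCO[C@H]1C[C@@H](c2coc3ccccc3c2=O)N(c2ccccc2)O1`: > 60000 nM
Compound 2 `CCO[C@H]1C[C@@H](c2coc3ccc(F)cc3c2=O)N(c2ccccc2)O1`: > 60000 nM
Compound 3 `CCO[C@H]1C[C@@H](c2coc3ccc(Br)cc3c2=O)N(c2ccccc2)O1`: > 60000 nM

In a functional assay on THP-1 cells (Homo sapiens) for inhibition, read by sulforhodamine B assay, with a stated time of 48 h (a higher number here means a weaker inhibitor, a lower number a stronger inhibitor), compound 1 gives > 60000 nM, which is a limit and not a number. The evidence so far is the limit of > 60000 nM in this assay, at which 3 of the 3 values shown sit. Compound 4 `NC(=O)[C@H]1C[C@@H](c2coc3ccccc3c2=O)N(c2ccccc2)O1` has carbamoyl in place of ethoxy on a saturated ring carbon, next to the ring oxygen (carbamoyl in place of ethoxy on a saturated ring carbon).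

Two measured changes offer the nearest comparison, although both are on an aromatic carbon rather than this saturated ring carbon. They are a step that the two limits leave unreadable from compound 1 to compound 2 and a step that the two limits leave unreadable from compound 1 to compound 3. Neither has a readable size, so they give no measure of how far a change in this series can move the result, and they point in no direction. The expected result in this assay is a number no higher from compound 1 to compound 4 (the limit leaves the size open), with another limit as the likeliest reading. Compound 4 is estimated at 60000 nM, with an expected range of 20000 nM to 100000 nM.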

Compound 4, half-maximal inhibitory concentration: > 60000 nM
Compound 4: no number, only a limit (the forecaster's own chance of this, stated with the estimate: 85%); the middle value lies on the limit itself.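

In this assay compound 4 gives > 60000 nM as a limit and not a number. Going by these compounds alone, compound 1 also gives only a limit, so no step from compound 1 to compound 4 can be read. Going by these compounds, what change to the shared core, if any, would give a readable number in this assay stays open.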